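Changing the aryl amide: cytotoxicity on human liver cells

The source may report more compounds than this note shows. Statements on the series, on what has been measured and on what is new or still open speak of the compounds shown alone.

Three compounds have been measured in an ADME assay on HepG2 cells (Homo sapiens) for cytotoxicity; on this read-out higher numbers stand for an effect only at larger amounts of compound and lower numbers for an effect already at smaller amounts:
Compound 1 `Cc1ccc(S(=O)(=O)N[C@@H](CC(=O)NC(C)(C)C)C(=O)NCCNC(=O)c2cc(C)ccc2F)cc1`: > 11000 nM.
Compound 2 `Cc1ccc(S(=O)(=O)N[C@@H](CC(=O)NC(C)(C)C)C(=O)NCCNC(=O)c2cc(Cl)ccn2)cc1`: > 11000 nM.
Compound 3 `Cc1ccc(S(=O)(=O)N[C@@H](CC(=O)NC(C)(C)C)C(=O)NCCNC(=O)c2ccc(Cl)cc2)cc1`: > 11000 nM.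

For compound 3 this value is a limit of the assay, not a number. For compound 2 it is likewise a limit. For compound 1 it is again a limit. Compound 2 therefore stands where every other measured compound stands, at the limit of > 11000 nM in this assay, at which 3 of the 3 values shown sit. The measured steps a step that the two limits leave unreadable from compound 1 to compound 2, a step that the two limits leave unreadable from compound 1 to compound 3 and a step that the two limits leave unreadable from compound 2 to compound 3 are all unreadable for this reason: none of them shows whether the aryl group changes the cytotoxicity.

Compound 4 `Cc1ccc(S(=O)(=O)N[C@@H](CC(=O)NC(C)(C)C)C(=O)NCCNC(=O)c2cccc(F)c2)cc1` differs from compound 2 by 3-fluorophenyl in place of 4-chloropyridin-2-yl on a carbonyl carbon. The earlier swaps of the aryl group left all compounds at the limit, so the step that the limit leaves unreadable from compound 2 to compound 4 is expected to be unreadable in the same way. Compound 4 is estimated to give 15000 nM, within 8000 nM to 30000 nM, most likely reported only as a limit.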

Compound 4, half-maximal effective concentration: > 11000 nM
Compound 4 ended at the assay's limit; the forecaster's own chance of this, stated with the estimate: 85%; the middle value does not contradict the limit.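

No step from compound 4 to compound 1, compound 2 or compound 3 can be read, because all four compounds sit at the same limit: the limit of > 11000 nM in this assay, at which 4 of the 4 values shown sit.

The compounds shown leave open whether changing the aryl group alters cytotoxicity at all.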